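The source may hold more compounds than are shown below. What is called first, only, known or untested is meant among the compounds shown, and "the series" means these compounds.

Compound 1 `O=C(Nc1ccccc1)c1cnc(NCc2c(F)ccc3c2CCO3)n2cnnc12`: 14 mL.min-1.g-1
Compound 2 `Cn1cc(-c2cnc(NCc3c(F)ccc4c3CCO4)c3cn[nH]c(=O)c23)cn1`: 21 mL.min-1.g-1
Compound 3 `CN(C)C(=O)c1cc(-c2cnc(NCc3c(F)ccc4c3CCO4)c3cn[nH]c(=O)c23)n(C)n1`: 21 mL.min-1.g-1

Of the compounds shown here, three have been measured in an ADME assay on microsomes from liver (Homo sapiens) for metabolic stability, read by LC-MS, using NADPH, with stated times of 5 min and 30 min, tested at 1 uM; on this read-out lower numbers stand for slow clearance and higher numbers for fast clearance. Compound 1 gives 14 mL.min-1.g-1, compound 2 gives 21 mL.min-1.g-1 and compound 3 gives 21 mL.min-1.g-1. Compound 1 stands within the scatter of both other compounds, so the three numbers are not separated on this read-out.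

The unmeasured compound 4 `C[C@H]1CC(=O)N(c2cnc(NCc3c(F)ccc4c3CCO4)n3cnnc23)C1` differs from compound 1 in one place: 4-methyl-2-oxopyrrolidin-1-yl in place of phenylcarbamoyl on an aromatic carbon. Among the measured compounds shown here, the only step measured so far, no change at the digits printed from compound 2 to compound 3 (within the scatter), changes a group on a different ring of a different core and does not touch the position altered here. It therefore bears on the present step only in showing that one sizeable change elsewhere left this assay unmoved. Nothing measured speaks to the place where compound 4 is changed.

In this assay compound 4 is expected to give about 15 mL.min-1.g-1, with a range from 7 mL.min-1.g-1 to 35 mL.min-1.g-1. The step of a 1.1-fold higher number from compound 1 to compound 4 (0.03 log units; within the scatter) is estimated to stay within the scatter.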

Compound 4, intrinsic clearance in microsomes: < 3 mL.min-1.g-1
Compound 4: no number, only a limit; the forecaster's own chance of this, stated with the estimate: 5%; middle value at least 5.0-fold (0.69 log units) away from the limit.
By their numbers in this assay, from the lowest: compounds 1, 2 and 3 (each within the scatter of the next). At a limit, below all of these: compound 4.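

In this assay, setting 4-methyl-2-oxopyrrolidin-1-yl in place of phenylcarbamoyl on this aromatic carbon gives an at least 4.6-fold lower number from compound 1 to compound 4 (0.66 log units; beyond the scatter), the only step shown that lies beyond the scatter. Among the compounds shown here, the earlier step, no change at the digits printed from compound 2 to compound 3 (within the scatter), changed another place on another core, so this is the first sign that the group at this position can move the read-out, here towards slow clearance. The true size of the step stays open, since compound 4 gives a limit and not a number: the limit of < 3 mL.min-1.g-1 in this assay, at which 1 of the 4 values shown sits.

The whole group changes at once, so the compounds shown do not separate the part played by the phenyl ring, the amide hydrogen, the ring methyl or its defined stereocentre. As far as these compounds go, how a simple amine, a carboxylic acid or the opposite stereoisomer of the 4-methyl-2-oxopyrrolidin-1-yl group would read at this position also remains open.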